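Replacing the nitro group of compound 2 with hydrogen

The compounds below may be only part of what the source reports. "The series", "measured", "known", "first", "only" and "open" are said of these compounds alone.

Of the compounds shown here, two sharing one core have been tested so far in a functional assay on NB-4 cells (Homo sapiens) for cytotoxicity, read by CCK-8 assay, with a stated time of 24 h; on this read-out higher numbers stand for weaker inhibition and lower numbers for stronger inhibition. There compound 1 (`C=CC(=O)N1C(=O)CC(c2ccc(OC)cc2)Sc2ccccc21`) gives 32900 nM and compound 2 (`C=CC(=O)N1C(=O)CC(c2ccc([N+](=O)[O-])cc2)Sc2ccccc21`) gives 37700 nM as its reading. Going by the values given here, compound 2 therefore lies within the usual scatter of compound 1, the only other number available, and neither can be ranked over the other.

Compound 3 (`C=CC(=O)N1C(=O)CC(c2ccccc2)Sc2ccccc21`) differs from compound 2 by one change (hydrogen in place of nitro on an aromatic carbon): hydrogen in place of nitro on an aromatic carbon, para to a large group. Among the compounds with values here, one measured step bears on this change, nitro in place of methoxy on an aromatic carbon, which gave a 1.1-fold higher number from compound 1 to compound 2 (0.06 log units; within the scatter) as its size. Within the data shown here, that is a single step, and no compound with hydrogen at this place has been measured yet, so the guide is thin. Among the measured compounds shown here, with that step as the only evidence, no change beyond the scatter is expected in this assay. The expected step is a 1.1-fold lower number from compound 2 to compound 3 (0.03 log units; within the scatter) and would sit within the scatter. For compound 3 the estimated value is 35000 nM with an expected range from 20000 nM to 60000 nM around it.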

Compound 3, half-maximal inhibitory concentration: 35500 nM
Compound 3: middle estimate off by 1.0-fold (0.01 log units), on the low side, within the range that was stated.
By their numbers in this assay, from the lowest: compounds 1, 3 and 2 (each within the scatter of the next).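

With compound 3, this place on the aromatic ring now has a plain hydrogen as a reference point, so the nitro and methoxy groups can each be judged against having no substituent there. In this assay, hydrogen in place of nitro gives (a 1.1-fold lower number from compound 2 to compound 3 (0.03 log units; within the scatter)), and hydrogen in place of methoxy gives (a 1.1-fold higher number from compound 1 to compound 3 (0.03 log units; within the scatter)), so neither group can be told apart from hydrogen at this place, para to a large group, and all three compounds read alike within the scatter. Nothing at hand explains why these three readings lie so close together.

As far as these compounds go, this result applies only to hydrogen, nitro and methoxy at this one place, so it remains open whether an amine, a carboxylic acid or a longer chain there would move the reading beyond the scatter. Also open, from the compounds shown here alone, is whether a change elsewhere on the shared core, rather than at this place, would separate compounds in this assay where these three do not.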